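Catechol Hydrazone Against a Bromophenol in the Cytotoxicity Series

The source may hold more compounds than are shown below. What is called first, only, known or untested is meant among the compounds shown, and "the series" means these compounds.

Three hydrazones built on the same core have been tested in a functional assay on MCF7 cells (Homo sapiens) for cytotoxicity, read by MTT assay, with a stated time of 48 h; a higher number here means a weaker inhibitor, a lower number a stronger inhibitor. Compound 1 `O=C(CSc1nnc(-c2ccncc2)o1)N/N=C/c1ccc(F)cc1` gives 13500 nM. Compound 2 `O=C(CSc1nnc(-c2ccncc2)o1)N/N=C/c1ccccc1O` gives 4750 nM, and compound 3 `O=C(CSc1nnc(-c2ccncc2)o1)N/N=C/c1cc(Br)ccc1O` gives 7770 nM. On these numbers compound 3 stands second highest of the three: its nearest neighbour is compound 2, and the step of a 1.6-fold higher number from compound 2 to compound 3 (0.21 log units; within the scatter) lies within the scatter, while the step of a 1.7-fold lower number from compound 1 to compound 3 (0.24 log units; within the scatter) also lies within the scatter. Within the data shown here, the only step beyond the scatter is a 2.8-fold lower number from compound 1 to compound 2 (0.45 log units; beyond the scatter).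

Compound 4 `O=C(CSc1nnc(-c2ccncc2)o1)N/N=C/c1ccc(O)c(O)c1` differs from compound 3 by 3,4-dihydroxyphenyl in place of 5-bromo-2-hydroxyphenyl on a carbon with a double bond to nitrogen. Among the measured compounds shown here, no measured pair shows this exact exchange. The bearing steps are the exchange of bromo for hydrogen, a 1.6-fold higher number from compound 2 to compound 3 (0.21 log units; within the scatter), which was within the scatter, and the exchange of a phenol for the fluorophenyl, a 2.8-fold lower number from compound 1 to compound 2 (0.45 log units; beyond the scatter), which was modest. Because compound 2 gives 4750 nM and compound 3 gives 7770 nM against compound 1 with 13500 nM, compound 4 is expected to stay near the two hydroxyl-bearing compounds, and the expected step is a 1.4-fold lower number from compound 3 to compound 4 (0.15 log units; within the scatter), not beyond the scatter. The estimate for compound 4 is 5500 nM, with a range from 2000 nM to 15000 nM.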

Compound 4, half-maximal inhibitory concentration: 910 nM
Compound 4: middle estimate off by 6.0-fold (0.78 log units), on the high side, outside the stated range (below it).
By their numbers in this assay, from the lowest: compound 4; then compounds 2, 3 and 1 (each within the scatter of the next, the first and the last beyond it).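

At this place, on a carbon with a double bond to nitrogen, the aryl group now makes a clear difference in this assay. The 3,4-dihydroxyphenyl group gives an 8.5-fold lower number from compound 3 to compound 4 (0.93 log units; beyond the scatter) against 5-bromo-2-hydroxyphenyl, a 5.2-fold lower number from compound 2 to compound 4 (0.72 log units; beyond the scatter) against 2-hydroxyphenyl and a 15-fold lower number from compound 1 to compound 4 (1.17 log units; beyond the scatter) against 4-fluorophenyl, whereas compound 2 and compound 3 lie within the scatter of each other, so the earlier hydroxyl-bearing compounds gave no sign of a shift this large. Nothing available explains why this group behaves so differently.

The compounds shown do not tell whether both hydroxyls of the 3,4-dihydroxyphenyl group are needed, or whether the effect depends on where they sit on the ring. Going by these compounds, what a methoxy group or an amine would give in place of these hydroxyls also remains open.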